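Thiophene to thiazole at the amine-bound carbon

The source may report more compounds than this note shows. Statements on the series, on what has been measured and on what is new or still open speak of the compounds shown alone.

Measured so far:
Compound 1, `C[C@H]1[C@H](NCc2cc(Br)cs2)C[C@H]2C[C@@H]1C2(C)C`, gives 6250 nM in an ADME assay on MDCK cells (Canis lupus familiaris) for cytotoxicity, read by microscopy, with a stated time of 48 h; on this read-out lower numbers stand for higher toxicity in this test and higher numbers for lower toxicity in this test.
Compound 2, `C[C@H]1[C@H](NCc2ccsc2)C[C@H]2C[C@@H]1C2(C)C`, gives 50000 nM in this assay.
Compound 3, `C[C@H]1[C@H](NCc2cccs2)C[C@H]2C[C@@H]1C2(C)C`, gives 25000 nM in this assay.

Among the three values, compound 3 lies between compound 2, which stays within the scatter of it (a 2.0-fold lower number from compound 2 to compound 3 (0.30 log units; within the scatter)), and compound 1, which lies beyond it (a 4.0-fold higher number from compound 1 to compound 3 (0.60 log units; beyond the scatter)). Compound 4, `Cc1csc(CN[C@@H]2C[C@H]3C[C@@H]([C@H]2C)C3(C)C)n1`, differs from compound 3 by 4-methyl-1,3-thiazol-2-yl in place of thiophen-2-yl on a saturated chain carbon bound to an amine nitrogen. Going by the values given here, no measured step exchanges one heteroaryl ring for a ring of another kind. Among the compounds with values here, the nearest comparison is a 2.0-fold lower number from compound 2 to compound 3 (0.30 log units; within the scatter), which stayed within the scatter, whereas the only step beyond it, a 4.0-fold higher number from compound 1 to compound 3 (0.60 log units; beyond the scatter), concerned a bromo substituent that is absent here. Compound 4 is therefore expected to show no step beyond the scatter in this assay, roughly no change at the digits printed from compound 3 to compound 4 (within the scatter). Compound 4 is estimated at 25000 nM, with a range from 8000 nM to 80000 nM.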

Compound 4, minimum cytotoxic concentration: > 100000 nM
Compound 4 ended at the assay's limit (the forecaster's own chance of this, stated with the estimate: 10%); at least 4.0-fold (0.60 log units) between middle value and limit.
By their numbers in this assay, from the lowest: compound 1; then compounds 3 and 2 (each within the scatter of the next). At a limit, above all of these: compound 4.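

In this assay, swapping one heteroaryl ring for a ring of another kind on a saturated chain carbon bound to an amine nitrogen gives a step beyond the scatter: an at least 4.0-fold higher number from compound 3 to compound 4 (0.60 log units; beyond the scatter). The wider comparisons are an at least 16-fold higher number from compound 1 to compound 4 (1.20 log units; beyond the scatter) and an at least 2.0-fold higher number from compound 2 to compound 4 (0.30 log units; that floor lies within the scatter), the second leaving compound 4 not yet separated from compound 2. Compound 4 stands at a limit, so these steps are floors: the limit of > 100000 nM in this assay, at which 1 of the 4 values shown sits.

The step does not separate the ring nitrogen from the methyl. 1,3-thiazol-2-yl without the methyl, or 4-methylthiophen-2-yl, would be the matching groups for that question.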